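This account rests on a few compounds, and the source may have more. Where it says the series, first, only, none or still open, it means among the compounds named here.

Working notes on the urea series, read-out an ADME assay on a cell-free system (plasma, Mus musculus) for protein binding. Compound 1 `CNc1nccc(N2CC[C@H](NC(=O)Nc3ccc(CN(C)C)c(C(F)(F)F)c3)C2)n1` gives 87.8%. Compound 2 `CNc1nccc(N2CC[C@H](NC(=O)Nc3ccc(OC)cc3)C2)n1` gives 82.1%, which lies within the scatter of compound 1. Compound 3 `CNc1nccc(N2CC[C@H](NC(=O)Nc3ccc(OC(F)(F)F)cc3)C2)n1` gives 98.1%, so compound 1 sits well clear of it, beyond the scatter, on the side where more of the compound is free.

Compound 4 `CCN1CCN(Cc2ccc(NC(=O)N[C@H]3CCN(c4ccnc(NC)n4)C3)cc2C(F)(F)F)CC1` keeps the core of compound 1 and changes one place: 4-ethylpiperazin-1-yl in place of dimethylamino on a saturated chain carbon bound to an aromatic carbon. In words, 4-ethylpiperazin-1-yl stands in place of dimethylamino on a saturated chain carbon bound to an aromatic carbon.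

Among the compounds with values here, only one measured step exists between close pairs: a 9.4-fold lower unbound fraction from compound 2 to compound 3 (0.97 log units; beyond the scatter). That step is trifluoromethyl in place of methyl on an oxygen on an aromatic ring, a different group at a different place. It shows that a single change can move this assay well beyond the scatter, but it gives no size for this change. Within the data shown here, no measured pair varies the amine on the saturated chain carbon, so the expectation stays close to compound 1 at 87.8%, with a slight lean towards more binding for the larger entering group.

The expected change is a 1.2-fold lower unbound fraction from compound 1 to compound 4 (0.09 log units; within the scatter), most likely within the scatter. The estimate for compound 4 is 90%, with an expected range of 80% to 96.5%.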

Compound 4, plasma protein binding: 85.4%
Compound 4: the middle estimate sits 1.5-fold (0.16 log units) (unbound fraction) below what was measured; measured number inside the range.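

Working from this pair, the amine on the saturated chain carbon bound to an aromatic carbon now has a measured exchange in this assay, which the earlier compounds did not provide. Replacing dimethylamino with 4-ethylpiperazin-1-yl gives a 1.2-fold higher unbound fraction from compound 1 to compound 4 (0.08 log units; within the scatter) and so stays within the scatter, even though the group grows from 3 to 8 heavy atoms and brings in a six-membered non-aromatic ring with 2 hetero atoms; in this one pair, neither the added size nor the added ring moves the read-out beyond the scatter. No measurement available here accounts for this result, so the pair records the outcome without explaining it.

One pair cannot show how far this holds at this place, and a morpholine, a carboxylic acid or a plain longer alkyl chain on the same saturated chain carbon would test whether any group there moves the read-out beyond the scatter. Also open, as far as these compounds go, is whether the same exchange gives a comparable result in a compound that carries a methoxy or trifluoromethoxy group on the aromatic ring in place of the trifluoromethyl group.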